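Methyl on the shared core: compound 4 still to be measured

The compounds below may be only part of what the source reports. "The series", "measured", "known", "first", "only" and "open" are said of these compounds alone.

Measured so far in an assay on brain for displacement of a labelled ligand from Sigma non-opioid intracellular receptor 1 (Cavia porcellus); on this read-out higher numbers stand for weaker inhibition and lower numbers for stronger inhibition:
compound 1 `C[C@]1(c2ccccc2)OCC[C@H](CCN)O1`, > 10000 nM (a limit of the assay, not a number)
compound 2 `NCC[C@H]1CCO[C@@H](c2ccccc2)O1`, > 10000 nM (also a limit)
compound 3 `c1ccc(CNCC[C@@H]2CCO[C@H](c3ccccc3)O2)cc1`, 6 nM

Compound 1 and compound 2 both sit at the limit, (the limit of > 10000 nM in this assay, at which 2 of the 3 values shown sit), so the step that the two limits leave unreadable from compound 2 to compound 1 cannot be read from them. Compound 3 carries the only number shown. How the core of compound 3 differs from the core of compound 2 is not broken down here.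

Compound 4 `C[C@@]1(c2ccccc2)OCC[C@@H](CCNCc2ccccc2)O1` is not yet measured. From compound 3 it differs by methyl in place of hydrogen on a saturated ring carbon. From compound 2 to compound 1 the change is methyl in place of hydrogen on a saturated ring carbon; the two are the same kind of change, the ring atom two ring bonds away bearing a 2-aminoethyl group (3 heavy atoms) in the first case and a large group in the second.

Since the measured step between compound 2 and compound 1 is unreadable, the expectation for compound 4 rests on compound 3 alone, whose value is 6 nM, and on the methyl adding only one heavy atom. The expected step from compound 3 to compound 4 in this assay is estimated as a 1.7-fold higher number from compound 3 to compound 4 (0.22 log units; within the scatter). Compound 4 is thus expected near 10 nM, between 3 nM and 60 nM.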

Compound 4, inhibition constant: 17 nM
Estimate against measurement, compound 4: 1.7-fold (0.23 log units) below; low and high end bracket the measured number.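

In this assay, methyl in place of hydrogen on a saturated ring carbon gives a 2.8-fold higher number from compound 3 to compound 4 (0.45 log units; beyond the scatter), a modest step that lies beyond the scatter, and compound 4 still has a measured number on the core that bears the large group. The same change on the core of compound 2, from compound 2 to compound 1, cannot be read, as both values are limits of the assay and not numbers: the limit of > 10000 nM in this assay, at which 2 of the 4 values shown sit. The series therefore offers a single readable instance of this change, which shows its size on one core only and does not show whether that size carries over to another core.

As far as these compounds go, whether ethyl in place of the methyl would give a step of similar size in this assay remains open. Also open, from the compounds shown here alone, is how the methyl step would read with a longer chain in place of the 2-aminoethyl group, or with a phenethyl group on the amine.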